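Bromo Removal on a Triazole-Bearing Tetracyclic Phenol

The compounds below may be only part of what the source reports. "The series", "measured", "known", "first", "only" and "open" are said of these compounds alone.

compound 1 `C=C1C[C@]23C[C@@]1(O)CC[C@H]2c1ccc(O)c(C)c1[C@@H]3Cn1cc(-c2ccccn2)nn1`: > 20000 nM
compound 2 `C=C1C[C@]23C[C@@]1(O)CC[C@H]2c1cc(Br)c(O)c(C)c1[C@@H]3Cn1cc(-c2ccccn2)nn1`: > 20000 nM
compound 3 `C=C1C[C@]23C[C@@]1(O)CC[C@H]2c1cc(Br)c(O)c(C)c1[C@@H]3Cn1cc(-c2ccc(Cl)cc2)nn1`: 10500 nM

In a functional assay on A549 cells (Homo sapiens) for cytotoxicity, read by MTT assay, with a stated time of 4 days (on this read-out lower numbers stand for stronger inhibition and higher numbers for weaker inhibition), compound 1 reaches only the limit > 20000 nM. Compound 2 likewise reaches only the limit > 20000 nM. Going by the values given here, compound 3 gives 10500 nM, the only number among the three. The change from compound 2 to compound 3 is 4-chlorophenyl in place of pyridin-2-yl on an aromatic carbon; the step is an at least 1.9-fold lower number from compound 2 to compound 3 (0.27 log units; that floor lies within the scatter). The change from compound 2 to compound 1 is hydrogen in place of bromo on an aromatic carbon; the step is a step that the two limits leave unreadable from compound 2 to compound 1, since both values sit at the limit of > 20000 nM in this assay, at which 2 of the 3 values shown sit.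

Compound 4 `C=C1C[C@]23C[C@@]1(O)CC[C@H]2c1ccc(O)c(C)c1[C@@H]3Cn1cc(-c2ccc(Cl)cc2)nn1` has not been measured in this assay. It differs from compound 3 by hydrogen in place of bromo on an aromatic carbon, the same change as that from compound 2 to compound 1, at the same place. That earlier step gives no readable size, so the expectation for compound 4 rests on compound 3 with 10500 nM and on the fact that two of the three values sit at the limit of > 20000 nM in this assay, at which 2 of the 3 values shown sit. The step expected from compound 3 to compound 4 is a 1.4-fold higher number from compound 3 to compound 4 (0.15 log units; within the scatter). Compound 4 is expected to give about 15000 nM, most likely between 6000 nM and 40000 nM, with a real chance that only a limit is reported.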

Compound 4, half-maximal inhibitory concentration: > 20000 nM
Compound 4: no number, only a limit; the forecaster's own chance of this, stated with the estimate: 45%; middle value at least 1.3-fold (0.12 log units) away from the limit.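

In this assay compound 4 gives > 20000 nM, which is a limit of the assay and not a number. From the compounds shown here alone, with the 4-chlorophenyl group in place, hydrogen in place of bromo gives an at least 1.9-fold higher number from compound 3 to compound 4 (0.27 log units; that floor lies within the scatter), so the pair shows no change beyond the scatter, and the true size of the step remains unknown. The same change on the pyridin-2-yl compounds cannot be read, nor can the step between compound 1 and compound 4, so the data neither confirm nor rule out that the bromo change has the same effect with both groups, because both members of each of these pairs sit at one limit: the limit of > 20000 nM in this assay, at which 3 of the 4 values shown sit.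

The compounds shown leave open whether chloro or methoxy in place of bromo, on the same aromatic carbon ortho to the hydroxy group, would give a readable number. They also leave open how an amine or a carboxylic acid would read in place of the 4-chlorophenyl group.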